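Cyclopropyl for methyl on the sulfonyl sulfur of compound 2

The compounds below may be only part of what the source reports. "The series", "measured", "known", "first", "only" and "open" are said of these compounds alone.

Among the measured compounds shown here, in an ADME assay on MT4 cells (Homo sapiens) for cytotoxicity, read by MTT assay, with a stated time of 5 days (a higher number here means that more compound is tolerated, a lower number that less compound is tolerated), compound 1 `Cc1cc(C)cc(S(=O)(=O)c2c(C(=O)N[C@@H]3CCNC3)[nH]c3ccc(Cl)cc23)c1` gives 37300 nM and compound 2 `Cc1cc(C)cc(S(=O)(=O)c2c(C(=O)NS(C)(=O)=O)[nH]c3ccc(Cl)cc23)c1` gives 40200 nM, so compound 2 stands within the scatter of the only other measured value. Compound 3 `Cc1cc(C)cc(S(=O)(=O)c2c(C(=O)NS(=O)(=O)C3CC3)[nH]c3ccc(Cl)cc23)c1` carries cyclopropyl in place of methyl on a sulfonyl sulfur. For the measured compounds named here, the one measured step with any bearing is a 1.1-fold higher number from compound 1 to compound 2 (0.03 log units; within the scatter), a change on an amide-type nitrogen that stays within the scatter. No step beyond the scatter is therefore expected in this assay, in either direction. The expected step is a 1.1-fold lower number from compound 2 to compound 3 (0.05 log units; within the scatter). For compound 3 the estimated value is 36000 nM, with an expected range of 15000 nM to 85000 nM.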

Compound 3, half-maximal cytotoxic concentration: 147000 nM
Compound 3: the middle estimate sits 4.1-fold (0.61 log units) below what was measured; the measured number lies above the stated range.
By their numbers in this assay, from the lowest: compounds 1 and 2 (each within the scatter of the next); then compound 3.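

In this assay the sulfonyl sulfur proves responsive to its substituent: cyclopropyl in place of methyl gives (a 3.7-fold higher number from compound 2 to compound 3 (0.56 log units; beyond the scatter)), a step beyond the scatter, whereas the earlier change on the amide-type nitrogen stayed within it. Cyclopropylsulfonyl in place of pyrrolidin-3-yl on that nitrogen gives a step of similar size (a 3.9-fold higher number from compound 1 to compound 3 (0.60 log units; beyond the scatter)), so compound 3 stands apart from both earlier compounds, with more compound tolerated. Nothing available explains this shift.

On these data alone, whether the rise is particular to cyclopropyl, or also appears with ethyl, isopropyl or phenyl on the same sulfonyl sulfur, stays open.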